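Chloro Added to Compound 1 in a Growth Assay

The source may hold more compounds than are shown below. What is called first, only, known or untested is meant among the compounds shown, and "the series" means these compounds.

Compound 1 `CC1=CC[C@H](C(C)(C)NC(=S)N/N=C/c2ccccc2)CC1` was tested in a functional assay on UACC-62 cells (Homo sapiens) for inhibition, read by sulforhodamine B assay, with a stated time of 48 h (on this read-out higher numbers stand for weaker inhibition of growth and lower numbers for stronger inhibition of growth), where it gives only a limit, > 100000 nM. Compound 2 `CC1=CC[C@H](C(C)(C)NC(=S)N/N=C/c2ccc(O)cc2)CC1` likewise gives only a limit in this assay, > 100000 nM. Compound 3 `CC1=CC[C@H](C(C)(C)NC(=S)N/N=C/c2ccc(F)cc2)CC1` also gives only a limit in this assay, > 100000 nM. The steps a step that the two limits leave unreadable from compound 1 to compound 2, a step that the two limits leave unreadable from compound 1 to compound 3 and a step that the two limits leave unreadable from compound 2 to compound 3 cannot be sized because of the limit of > 100000 nM in this assay, at which 3 of the 3 values shown sit. Compound 4 `CC1=CC[C@H](C(C)(C)NC(=S)N/N=C/c2ccccc2Cl)CC1` differs from compound 1 by chloro in place of hydrogen on an aromatic carbon. Among the compounds with values here, no measured step bears directly on this change; the three limits show only that hydroxy and fluoro on the same ring gave no readable number. Compound 4 is therefore expected to show a step that the limit leaves unreadable from compound 1 to compound 4 and most likely to return another limit. The estimate for compound 4 is 150000 nM, with a range from 40000 nM to 600000 nM.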

Compound 4, concentration for total growth inhibition: 98000 nM
The estimate for compound 4 lay 1.5-fold (0.18 log units) above the measured number; the measured number falls inside the stated range.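

Within the data shown here, with chloro on an aromatic carbon, ortho to a large group, compound 4 is the only compound in this assay to give a number rather than a limit. The change reads as an at least 1.0-fold lower number from compound 1 to compound 4 (0.00 log units; that floor lies within the scatter), as an at least 1.0-fold lower number from compound 3 to compound 4 (0.00 log units; that floor lies within the scatter) and as an at least 1.0-fold lower number from compound 2 to compound 4 (0.00 log units; that floor lies within the scatter), so no gain in inhibition of growth can be claimed from it. Each of these steps is only a floor because the other three compounds give no number: the limit of > 100000 nM in this assay, at which 3 of the 4 values shown sit.

From the compounds shown here alone, whether bromo, an amine or a nitrile in place of the chloro would give a number clearly lower than that of compound 4 stays open.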